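One Hydroxy Fewer: Expected Effect on Growth Inhibition

The source may report more compounds than this note shows. Statements on the series, on what has been measured and on what is new or still open speak of the compounds shown alone.

Measured compounds in a functional assay on DU-145 cells (Homo sapiens) for inhibition, read by trypan blue exclusion, with a stated time of 96 h; a higher number here means a weaker inhibitor of growth, a lower number a stronger inhibitor of growth:
- compound 1 `COc1ccc(/C=C(\C(=O)c2ccc(Cl)cc2)S(=O)(=O)c2ccc(Br)cc2)cc1O` gives 10000 nM
- compound 2 `COc1ccc(/C=C(\C(=O)c2ccc(Cl)cc2)S(=O)(=O)c2ccc(Br)cc2)cc1` gives 10000 nM
- compound 3 `O=C(/C(=C\c1c(O)cc(O)cc1O)Sc1ccccc1Br)c1ccc(Cl)cc1` gives only a limit of the assay, > 100000 nM

Compound 1 and compound 2 share a core and differ by hydrogen in place of hydroxy on an aromatic carbon. That step, no change at the digits printed from compound 1 to compound 2 (within the scatter), shows the loss of this hydroxy made no difference there. Compound 3 sits at the limit (the limit of > 100000 nM in this assay, at which 1 of the 3 values shown sits), so its value is a bound and not a number. How the core of compound 3 differs from the core of compound 1 is not broken down here.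

Compound 4 `O=C(/C(=C\c1ccc(O)cc1O)Sc1ccccc1Br)c1ccc(Cl)cc1` is not yet measured. It differs from compound 3 by hydrogen in place of hydroxy on an aromatic carbon. This is the same kind of change as from compound 1 to compound 2, not the same one: in compound 1 the hydroxy sits ortho to a methoxy group and meta to a large group, whereas in compound 3 it sits ortho to a large group and meta to two hydroxy groups.

Going by the earlier step, compound 4 is expected to stay near its parent, a step of a number no higher from compound 3 to compound 4 (the limit leaves the size open), and so is estimated at 100000 nM in this assay.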

Compound 4, concentration for 50% growth inhibition: 50000 nM
Compound 4: middle estimate off by 2.0-fold (0.30 log units), on the high side, and the stated range covers the measured number.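

In this assay, putting hydrogen in place of a hydroxy, the step from 2,4,6-trihydroxyphenyl to 2,4-dihydroxyphenyl, gives an at least 2.0-fold lower number from compound 3 to compound 4 (0.30 log units; that floor lies within the scatter). Compound 3 gives only a limit of the assay, > 100000 nM, so this step has a floor but no known size. Set beside the earlier case, this neither shows that the change carries over from one core to the other with the same effect nor shows that its effect depends on the core: the same change on two cores in this assay, no change at the digits printed (within the scatter) from compound 1 to compound 2 and an at least 2.0-fold lower number (0.30 log units; that floor lies within the scatter) from compound 3 to compound 4; the limit leaves it open whether they differ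

The compounds shown leave open what an amine or a carboxylic acid would do in place of this hydroxy on the same aromatic carbon. Also open, on these data alone, is what taking a further hydroxy from the 2,4-dihydroxyphenyl group of compound 4 would do, and how large the step would be from a parent with a measured number rather than a limit.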